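Mixed amidine–guanidine analogue in the bis-aryl series

A few compounds are considered here, and "the series" means these few. Any claim that something is new, unique, unknown or untested is made for them only; others in the source may bear on it.

Compound 1 `N=C(N)c1ccc(C(=O)NCC(=O)N2CCN(CC(=O)O)C(=O)[C@@H]2CNC(=O)c2ccc(C(=N)N)cc2)cc1` gives 120 nM in a functional assay for inhibition, with Cavia porcellus as the target; on this read-out lower numbers stand for stronger inhibition and higher numbers for weaker inhibition. Compound 2 `N=C(N)c1ccc(C(=O)NCCC[C@H]2C(=O)N(CC(=O)O)CCN2C(=O)CNC(=O)c2ccc(C(=N)N)cc2)cc1` gives 37 nM in this assay. Compound 3 `N=C(N)Nc1ccc(C(=O)NCCC[C@H]2C(=O)N(CC(=O)O)CCN2C(=O)CNC(=O)c2ccc(NC(=N)N)cc2)cc1` gives 51 nM in this assay, the second highest of the three numbers: compound 2 is within the scatter of it, while compound 1 lies beyond the scatter at the higher end. Compound 4 `N=C(N)Nc1ccc(C(=O)NCCC[C@H]2C(=O)N(CC(=O)O)CCN2C(=O)CNC(=O)c2ccc(C(=N)N)cc2)cc1` is not yet measured; it differs from compound 3 by a group of 3 heavy atoms (1 carbon, 2 nitrogen; no ring) in place of a group of 4 heavy atoms (1 carbon, 3 nitrogen; no ring), on an aromatic carbon. Since compound 2 and compound 3 sit within the scatter of each other, no step beyond the scatter is expected: a 1.1-fold lower number from compound 3 to compound 4 (0.05 log units; within the scatter). Compound 4 is expected to give 45 nM, in the range 20 nM to 100 nM.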

Compound 4, half-maximal inhibitory concentration: 19 nM
Compound 4: middle estimate off by 2.4-fold (0.37 log units), on the high side; the whole stated range lies above it.
By their numbers in this assay, from the lowest: compounds 4, 2 and 3 (each within the scatter of the next, the first and the last beyond it); then compound 1.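

In this assay, replacing the guanidine with the amidine on one arm, with the other arm held as guanidine, gives a 2.7-fold lower number from compound 3 to compound 4 (0.43 log units; beyond the scatter), so this position responds to the change when the second arm carries a guanidine. On the other arm, replacing the amidine with the guanidine gives a 1.9-fold lower number from compound 2 to compound 4 (0.29 log units; within the scatter), so a step of that kind does not show there. Nothing available explains the step at the first position.

From the compounds shown here alone, it remains open whether a primary amine on the aromatic carbon would retain the number seen with the amidine. Also open, going by these compounds, is how a carboxylic acid at that place would read.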